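The compounds below may be only part of what the source reports. "The series", "measured", "known", "first", "only" and "open" are said of these compounds alone.

Measured compounds in a functional assay on the whole organism (6C3HED cells, Mus musculus) for inhibition, at a dose of 300 mg/kg by the oral route; on this read-out lower numbers stand for less inhibition and higher numbers for more inhibition at the one dose given (going by the name of the read-out):

compound 1 `COc1ccc(S(=O)(=O)NC(=O)Nc2ccc(Cl)cc2)s1` gives 100%
compound 2 `CCCc1ccc(S(=O)(=O)NC(=O)Nc2ccc(Cl)cc2)s1` gives 39%
compound 3 `CC(C)c1ccc(S(=O)(=O)NC(=O)Nc2ccc(Cl)cc2)s1` gives 63%

Compound 1 stands highest of the three; its steps to compound 3 and to compound 2 are both beyond the scatter, so its number in this assay is the highest of the measured set.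

Compound 4 `Cc1ccsc1S(=O)(=O)NC(=O)Nc1ccc(Cl)cc1` is the next compound to be tested. The change from compound 1 is 3-methylthiophen-2-yl in place of 5-methoxythiophen-2-yl on a sulfonyl sulfur.

The measured steps that bear on this are those in which methoxy on the aromatic carbon gives way to an alkyl group: a number 61 percentage points lower from compound 1 to compound 2 (beyond the scatter) and a number 37 percentage points lower from compound 1 to compound 3 (beyond the scatter). Both are large drops. Between the two alkyl groups, a number 24 percentage points higher from compound 2 to compound 3 (beyond the scatter) is modest. Within the data shown here, no measured compound carries a substituent at the position that the entering methyl occupies, so that part of the change has no direct precedent here. On balance a large fall in this assay is expected, and compound 4 is estimated at 55% (range 25% to 90%), meaning an expected step of a number 45 percentage points lower from compound 1 to compound 4 (beyond the scatter).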

Compound 4, a percentage reported as inhibition, in the whole organism at one dose (the size of the read-out at that dose, not a potency): 62%
The estimate for compound 4 lay 7 percentage points below the measured number; the range from low to high includes it.
By their numbers in this assay, from the lowest: compound 2; then compounds 4 and 3 (each within the scatter of the next); then compound 1.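

In this assay the exchange of 5-methoxythiophen-2-yl for 3-methylthiophen-2-yl on the sulfonyl sulfur gives a number 38 percentage points lower from compound 1 to compound 4 (beyond the scatter) as a large step, so a compound without the methoxy group and with its methyl in a new place still keeps much of the inhibition at this dose, with compound 4 at 62% on this read-out. The step combines the departure of methoxy with the arrival of the 3-methyl group, and this single pair cannot assign the fall to either part. No measurement at hand accounts for the size of this step.

On these data alone, the separate contributions remain open, and the unsubstituted thiophen-2-yl, 5-methylthiophen-2-yl and 3-methoxythiophen-2-yl groups would divide them. As far as these compounds go, whether the inhibition survives an amine or a carboxylic acid on the same ring also remains open.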